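Dropping a Methoxy Group from a Compound at the Limit

A few compounds are considered here, and "the series" means these few. Any claim that something is new, unique, unknown or untested is made for them only; others in the source may bear on it.

Of the compounds shown here, three have so far been tested in a functional assay on Raji cells (Homo sapiens); a lower number here means a stronger inhibitor, a higher number a weaker inhibitor. Compound 1 `CCC1(C)OC(/C(C)=C/COc2ccc3ccc(=O)oc3c2)=CC1=N` gives 17.9 ug/mL in this assay, and compound 2 `C/C(=C\CO)CC1=CC(=O)C(C)(C)O1` gives 16.6 ug/mL; these two values lie within the usual scatter of each other. Compound 3 `COc1ccccc1C1=CC(=O)CO1` stands elsewhere: in this assay it returns only a limit of the measurement, > 100 ug/mL, so no number is known for it. Among the compounds with values here, compound 3 is thus the one compound for which this assay sits at the limit of > 100 ug/mL in this assay, at which 1 of the 3 values shown sits, rather than at a value.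

The next compound, compound 4 `O=C1C=C(c2ccccc2)OC1`, comes from compound 3 by a single change: hydrogen in place of methoxy on an aromatic carbon. The methoxy leaves and a hydrogen enters on an aromatic carbon of a six-membered aromatic ring of carbon only. Within the data shown here, no step between two measured compounds is available to show how such a change acts in this assay. Because compound 3 already sits at the limit of > 100 ug/mL in this assay, at which 1 of the 3 values shown sits, the expectation is for a number no higher from compound 3 to compound 4 (the limit leaves the size open), no movement beyond the scatter. Compound 4 is accordingly estimated at 100 ug/mL, with a range from 30 ug/mL to 300 ug/mL, and it may well return only a limit again.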

Compound 4, concentration for 50% inhibition: 50.1 ug/mL
Beside the measured number, compound 4's estimate is 2.0-fold (0.30 log units) above it; the measured number falls inside the stated range.
By their numbers in this assay, from the lowest: compounds 2 and 1 (each within the scatter of the next); then compound 4. At a limit, above all of these: compound 3.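

In this assay, within the data shown here, the swap of methoxy for hydrogen on this aromatic carbon is the first change at this position that can be read at all, and it gives an at least 1.9-fold lower number from compound 3 to compound 4 (0.30 log units; that floor lies within the scatter). That figure is only a floor, because compound 3 stands at a limit of the measurement and not at a number: the limit of > 100 ug/mL in this assay, at which 1 of the 4 values shown sits. Compound 4, with hydrogen at this place, gives 50.1 ug/mL, so the bare aromatic ring now has a true number, against which other groups at this place could be set.

As far as these compounds go, how large the real step from the methoxy compound is stays open, and it may or may not exceed the usual scatter. Also open, from the compounds shown here alone, is what another group on this carbon, such as a fluorine, a hydroxyl or an amine, would do in this assay.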